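This account rests on a few compounds, and the source may have more. Where it says the series, first, only, none or still open, it means among the compounds named here.

Compounds measured in a functional assay on HT-29 cells (Homo sapiens) for cytotoxicity, read by MTT assay, with a stated time of 72 h; a higher number here means a weaker inhibitor, a lower number a stronger inhibitor:
compound 1 `COc1ccc(NC(=O)CN2CCN(c3nnc(Cc4ccncc4)c4ccccc34)CC2)cc1OC` gives 40100 nM
compound 2 `O=C(CN1CCN(c2nnc(Cc3ccncc3)c3ccccc23)CC1)Nc1ccc(F)c(C(F)(F)F)c1` gives 1110 nM
compound 3 `COc1ccc(NC(=O)CN2CCN(c3nnc(Cc4ccccc4)c4ccccc34)CC2)cc1OC` gives 145000 nM

Compound 3 has the highest number of the three. Its nearest neighbour is compound 1, separated by the step of a 3.6-fold higher number from compound 1 to compound 3 (0.56 log units; beyond the scatter), which turns on the pyridin-4-yl of compound 1 against the phenyl of compound 3. Among the measured compounds shown here, compound 2 at 1110 nM lies far below compound 3 at 145000 nM; no single-change step joins these two.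

Compound 4 `O=C(CN1CCN(c2nnc(Cc3ccccc3)c3ccccc23)CC1)Nc1cc(C(F)(F)F)ccc1Cl` is the next entry. Relative to compound 3 the change is 2-chloro-5-(trifluoromethyl)phenyl in place of 3,4-dimethoxyphenyl on an amide-type nitrogen. For the measured compounds named here, the one measured step that bears on it is a 36-fold lower number from compound 1 to compound 2 (1.56 log units; beyond the scatter), where the same 3,4-dimethoxyphenyl on the amide-type nitrogen gave way to a halogenated trifluoromethyl-bearing phenyl, on a core carrying pyridin-4-yl rather than phenyl. The entering group in compound 4 is not the same as in compound 2, so the size of the effect is not fixed by that step alone, but the direction is expected to carry over: a clearly lower number, beyond the scatter. The step from compound 3 to compound 4 is estimated at a 21-fold lower number from compound 3 to compound 4 (1.32 log units; beyond the scatter). Compound 4 is accordingly expected near 7000 nM, within 2000 nM to 30000 nM, in this assay.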

Compound 4, half-maximal inhibitory concentration: 66800 nM
For compound 4 the middle estimate is 9.5-fold (0.98 log units) below the measured one; measured number above the stated range.
By their numbers in this assay, from the lowest: compound 2; then compounds 1 and 4 (each within the scatter of the next); then compound 3.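

In this assay, on the core that carries phenyl rather than pyridin-4-yl, 2-chloro-5-(trifluoromethyl)phenyl in place of 3,4-dimethoxyphenyl on the amide-type nitrogen gives a 2.2-fold lower number from compound 3 to compound 4 (0.34 log units; beyond the scatter), a modest step in the same direction as but much smaller than a 36-fold lower number from compound 1 to compound 2 (1.56 log units; beyond the scatter). The large earlier step therefore does not hold for every replacement of 3,4-dimethoxyphenyl by a halogenated trifluoromethyl-bearing phenyl, although these two steps differ in both the entering group and the core, so neither difference can be singled out as the one that sets the size. No measurement is at hand that accounts for the smaller step.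

Still open, as far as these compounds go, is how each of the two entering groups behaves on the other core: 4-fluoro-3-(trifluoromethyl)phenyl with phenyl in place of pyridin-4-yl, and 2-chloro-5-(trifluoromethyl)phenyl with pyridin-4-yl in place of phenyl. The compounds shown also say nothing about how a phenyl bearing a carboxylic acid or a dimethylamino group would read on the amide-type nitrogen.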